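A few compounds are considered here, and "the series" means these few. Any claim that something is new, unique, unknown or untested is made for them only; others in the source may bear on it.

Within the data shown here, in a functional assay on MCF7 cells (Homo sapiens) for antiproliferative activity, read by XTT assay, with a stated time of 72 h (on this read-out lower numbers stand for stronger inhibition and higher numbers for weaker inhibition), compound 2 `COc1ccc(-c2cc3ccccc3nc2/C=C/C(=O)c2ccco2)cc1` gives 710 nM, the lowest of the two numbers known; compound 1 `COc1ccc(-c2cc3ccccc3nc2/C=C/C(=O)c2ccc(OC)cc2OC)cc1` gives 6260 nM, and the step of an 8.8-fold lower number from compound 1 to compound 2 (0.95 log units; beyond the scatter) is the only one recorded. Compound 3 `COc1ccc(-c2cc3ccccc3nc2/C=C/C(=O)c2ccc[nH]2)cc1` differs from compound 2 by 1H-pyrrol-2-yl in place of furan-2-yl on a carbonyl carbon. Among the measured compounds shown here, no measured step exchanges one five-membered ring for another on the carbonyl carbon, so the recorded step offers only a loose guide to the size of this change. A step of about the scatter's size is therefore expected, a 1.3-fold higher number from compound 2 to compound 3 (0.10 log units; within the scatter). Compound 3 is estimated at 900 nM, within 300 nM to 2700 nM.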

Compound 3, half-maximal inhibitory concentration: > 10000 nM
Compound 3 was reported as a limit (the forecaster's own chance of this, stated with the estimate: 3%); middle value at least 11-fold (1.04 log units) away from the limit.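

At this carbonyl carbon, 1H-pyrrol-2-yl in place of furan-2-yl gives an at least 14-fold higher number from compound 2 to compound 3 (1.14 log units; beyond the scatter), so these two five-membered aromatic rings, each with 5 heavy atoms, are not interchangeable here. On these data alone, the value of compound 3 is a limit of the assay, and the true size of the step stays unknown: the limit of > 10000 nM in this assay, at which 1 of the 3 values shown sits. Against 2,4-dimethoxyphenyl, the change gives an at least 1.5-fold higher number from compound 1 to compound 3 (0.20 log units; that floor lies within the scatter), so compound 1 and compound 3 cannot be ordered. The compounds shown leave open whether the loss goes with the hydrogen-bond donor of 1H-pyrrol-2-yl, and how 1-methyl-1H-pyrrol-2-yl or thiophen-2-yl would behave on this carbonyl carbon.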